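Swapping the 2-Hydroxyphenyl for a 3-Chlorophenyl

A few compounds are considered here, and "the series" means these few. Any claim that something is new, unique, unknown or untested is made for them only; others in the source may bear on it.

Of the compounds shown here, three built on one shared core have been tested in a functional assay on UACC-62 cells (Homo sapiens) for inhibition, read by sulforhodamine B assay, with a stated time of 48 h; a higher number here means a weaker inhibitor of growth, a lower number a stronger inhibitor of growth. Compound 1, `CC1=CC[C@H](C(C)(C)NC(=S)N/N=C/c2ccccc2)CC1`, bears an unsubstituted phenyl ring. In this assay compound 1 reaches only the limit of the assay, > 100000 nM, and so gives no number. Compound 2, `CC1=CC[C@H](C(C)(C)NC(=S)N/N=C/c2ccc(O)cc2)CC1`, carries a 4-hydroxyphenyl. In this assay compound 2 also stops at the limit, > 100000 nM. Among the compounds with values here, compound 3, `CC1=CC[C@H](C(C)(C)NC(=S)N/N=C/c2ccccc2O)CC1`, carries a 2-hydroxyphenyl and is the only compound with a real number: in this assay compound 3 gives 10800 nM. The step of an at least 9.2-fold lower number from compound 1 to compound 3 (0.96 log units; beyond the scatter) and the step of an at least 9.2-fold lower number from compound 2 to compound 3 (0.96 log units; beyond the scatter) both point to the 2-hydroxyphenyl as what sets compound 3 apart. The step that the two limits leave unreadable from compound 1 to compound 2 cannot be sized because both ends sit at the limit of > 100000 nM in this assay, at which 2 of the 3 values shown sit.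

Compound 4, `CC1=CC[C@H](C(C)(C)NC(=S)N/N=C/c2cccc(Cl)c2)CC1`, differs from compound 3 by 3-chlorophenyl in place of 2-hydroxyphenyl on a carbon with a double bond to nitrogen. The 2-hydroxyphenyl that carried compound 3 below the limit is gone, and the 3-chlorophenyl brings no hydrogen-bond donor or acceptor. The two readable steps therefore suggest a move back towards the limit, and the step is expected to be a 5.6-fold higher number from compound 3 to compound 4 (0.74 log units; beyond the scatter). Compound 4 is estimated at 60000 nM, with a range from 15000 nM to 200000 nM, and a fair chance that only a limit is reported.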

Compound 4, concentration for total growth inhibition: 39800 nM
Beside the measured number, compound 4's estimate is 1.5-fold (0.18 log units) above it; the measured number falls inside the stated range.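

In this assay, within the data shown here, a hydroxy group is not the only change on this aromatic ring that gives a readable number: chloro in place of hydrogen gives an at least 2.5-fold lower number from compound 1 to compound 4 (0.40 log units; beyond the scatter), and 3-chlorophenyl in place of 4-hydroxyphenyl gives an at least 2.5-fold lower number from compound 2 to compound 4 (0.40 log units; beyond the scatter). The 3-chlorophenyl counts no hydrogen-bond donors or acceptors, so on this set a donor on the ring is not needed for a number below the limit, although both of these steps start from a limit and give only a smallest possible size, not a true one: the limit of > 100000 nM in this assay, at which 2 of the 4 values shown sit. Even so, the two groups are not interchangeable on a carbon with a double bond to nitrogen, since the 2-hydroxyphenyl keeps a clear lead, with a 3.7-fold higher number from compound 3 to compound 4 (0.57 log units; beyond the scatter).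

With a single chloro compound, these results cannot show whether chloro itself matters or whether any group other than hydrogen on the ring would do the same. A phenyl ring carrying a methoxy, a bromo or an amine in place of the chloro would help to separate those two readings, and would show how far the number can move at this place on the shared core.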